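Benzyl ether series at the alpha-1D receptor: ring substitution moves

The source may hold more compounds than are shown below. What is called first, only, known or untested is meant among the compounds shown, and "the series" means these compounds.

Measured compounds:
compound 1 `COc1cccc(OC)c1OCCNCCOc1ccccc1OCc1ccccc1Cl` gives 0.251 nM
compound 2 `COc1cccc(OC)c1OCCNCCOc1ccccc1OCc1cccc(Cl)c1` gives 0.0501 nM
compound 3 `COc1ccccc1COc1ccccc1OCCNCCOc1c(OC)cccc1OC` gives 2 nM

All three compounds share one core and differ only in the group on the saturated chain carbon bound to an oxygen on an aromatic ring. In an assay on CHO cells for displacement of a labelled ligand from Alpha-1D adrenergic receptor (Homo sapiens) (on this read-out higher numbers stand for weaker inhibition and lower numbers for stronger inhibition), compound 3 stands with the highest number of the three: an 8.0-fold higher number from compound 1 to compound 3 (0.90 log units; beyond the scatter), and a 40-fold higher number from compound 2 to compound 3 (1.60 log units; beyond the scatter).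

The unmeasured compound 4 `COc1cccc(COc2ccccc2OCCNCCOc2c(OC)cccc2OC)c1` is reached from compound 3 by 3-methoxyphenyl in place of 2-methoxyphenyl on a saturated chain carbon bound to an oxygen on an aromatic ring.

Going by the values given here, the one measured step that bears directly on this move is the matching shift of the chloro group from compound 1 to compound 2, where the chlorophenyl group was moved in the same way: a 5.0-fold lower number from compound 1 to compound 2 (0.70 log units; beyond the scatter). Among the compounds with values here, no measured pair shows the same shift for a methoxyphenyl group, so the transfer rests on that single chloro step. A lower number for compound 4 than for compound 3 is therefore expected in this assay, of modest size, and the step is estimated as a 4.0-fold lower number from compound 3 to compound 4 (0.60 log units; beyond the scatter). For compound 4 the estimated value is 0.5 nM, with a range from 0.15 nM to 1.6 nM.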

Compound 4, inhibition constant: 0.316 nM
Compound 4: the middle estimate sits 1.6-fold (0.20 log units) above what was measured; low and high end bracket the measured number.
By their numbers in this assay, from the lowest: compound 2; then compounds 1 and 4 (each within the scatter of the next); then compound 3.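

In this assay, 3-methoxyphenyl in place of 2-methoxyphenyl gives a 6.3-fold lower number from compound 3 to compound 4 (0.80 log units; beyond the scatter), so the direction of a 5.0-fold lower number from compound 1 to compound 2 (0.70 log units; beyond the scatter) now holds for a second group at this position. Going from the 3-chlorophenyl to the 3-methoxyphenyl group gives a 6.3-fold higher number from compound 2 to compound 4 (0.80 log units; beyond the scatter), and methoxy in place of chloro therefore carries a step of like size with either arrangement on the ring: the same change on two cores in this assay, an 8.0-fold higher number (0.90 log units; beyond the scatter) from compound 1 to compound 3 and a 6.3-fold higher number (0.80 log units; beyond the scatter) from compound 2 to compound 4, 1.3-fold (0.10 log units) apart, within the scatter of two such steps. The 3-methoxyphenyl and 2-chlorophenyl groups cannot be told apart here, as a 1.3-fold higher number from compound 1 to compound 4 (0.10 log units; within the scatter) shows.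

Going by these compounds, whether a fluoro, hydroxy or dimethylamino group on the phenyl ring, or an unsubstituted phenyl, would fit the same pattern stays open. The pattern also rests on two pairs on the shared core, so it says nothing about other cores or other assays.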